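Compound 4: thiophen-2-yl in place of 3-methylphenyl

The compounds below may be only part of what the source reports. "The series", "measured", "known", "first", "only" and "open" are said of these compounds alone.

Compound 1, `CC(C)CCCN(C(=O)[C@@H]1C[C@H]1c1ccccc1)c1ccc(-c2ccccc2)cc1`: in a functional assay for agonist activity at G protein-coupled receptor 88 (Homo sapiens), read by HTRF and cAMP accumulation (a higher number here means that more compound is needed for the effect, a lower number that less compound is needed), compound 1 gives only the assay limit > 100 nM.
Compound 2, `O=C([C@@H]1C[C@H]1c1ccccc1)N(CC1CCCNC1)c1ccc(-c2ccccc2)cc1`: compound 2 gives 10 nM.
Compound 3, `CC[C@H](C)[C@H](N)CN(C(=O)[C@@H]1C[C@H]1c1cccc(C)c1)c1ccc(-c2ccccc2)cc1`: compound 3 gives 1200 nM.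

Among the two numbers shown, compound 3 carries the higher one, with compound 2 well below it. Compound 4, `CC[C@H](C)[C@H](N)CN(C(=O)[C@@H]1C[C@H]1c1cccs1)c1ccc(-c2ccccc2)cc1`, differs from compound 3 in one place: thiophen-2-yl in place of 3-methylphenyl on a saturated ring carbon. For the measured compounds named here, the only measured step, an at least 10-fold lower number from compound 1 to compound 2 (1.00 log units; beyond the scatter), changes the group on the amide-type nitrogen and leaves the aryl on the three-membered ring untouched, so it offers no guide to this change; compound 1 sits at the limit (the limit of > 100 nM in this assay, at which 1 of the 3 values shown sits). Going by the values given here, with no measured step at the aryl position, the expected change is none beyond the scatter, no change at the digits printed from compound 3 to compound 4 (within the scatter). Compound 4 is therefore estimated at 1200 nM, between 400 nM and 3600 nM.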

Compound 4, half-maximal effective concentration: 360 nM
Beside the measured number, compound 4's estimate is 3.3-fold (0.52 log units) above it; measured number below the stated range.
By their numbers in this assay, from the lowest: compound 2; then compound 4; then compound 3.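

At this saturated ring carbon of the three-membered ring, the aryl group is not a silent part of the structure in this assay: thiophen-2-yl in place of 3-methylphenyl gives a 3.3-fold lower number from compound 3 to compound 4 (0.52 log units; beyond the scatter). The position therefore accepts a five-membered aromatic ring with a sulfur atom in place of the methyl-bearing six-membered ring, without a higher number. No measurement shown here accounts for the shift.

Going by these compounds, whether phenyl, furan-2-yl or pyridin-3-yl would behave like thiophen-2-yl here remains open. So does whether the same change would carry over alongside the piperidin-3-yl group of compound 2.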